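A few compounds are considered here, and "the series" means these few. Any claim that something is new, unique, unknown or untested is made for them only; others in the source may bear on it.

Compound 2 `CCn1cc(C(CC)(CC)c2ccc(C#CC(O)(CC)CC)c(C)c2)cc1C(=O)NCC(=O)OC`: 288 nM
Compound 1 `CCn1c(C(=O)On2nnc3ccccc32)ccc1C(CC)(CC)c1ccc(C#CC(O)(CC)CC)c(C)c1`: > 50 nM (a limit of the assay, not a number)

Among the measured compounds shown here, in an assay on cells for agonist activity at vitamin D3 receptor (Homo sapiens), read by microscopy (a lower number here means that less compound is needed, a higher number that more compound is needed for the effect), compound 2 gives 288 nM, the only number among the two values shown. For compound 1, the limit of > 50 nM in this assay, at which 1 of the 2 values shown sits, is a limit of the assay and not a number. Compound 3 `CCN(CC)CCNC(=O)c1cc(C(CC)(CC)c2ccc(C#CC(O)(CC)CC)c(C)c2)cn1CC` has not been measured. It differs from compound 2 by (diethylamino)methyl in place of methoxycarbonyl on a saturated chain carbon bound to an amide-type nitrogen. No measured step between any two of these compounds exists, so nothing indicates a direction; the step is expected to be a 1.0-fold higher number from compound 2 to compound 3 (0.02 log units; within the scatter), nothing beyond the usual scatter. Compound 3 is therefore estimated at 300 nM, within a range from 80 nM to 1200 nM.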

Compound 3, half-maximal effective concentration: 6.98 nM
For compound 3 the middle estimate is 43-fold (1.63 log units) above the measured one; measured number below the stated range.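

In this assay, putting (diethylamino)methyl in place of methoxycarbonyl on a saturated chain carbon bound to an amide-type nitrogen gives a 41-fold lower number from compound 2 to compound 3 (1.62 log units; beyond the scatter). Among the compounds shown here, this is the first readable step, and it shows that the number responds strongly to what sits at this end of the chain. Nothing shown explains why the step is so large.

Still open, going by these compounds, is whether the amine nitrogen itself is needed, which a plain butyl group or a carboxylic acid at this place would test. On these data alone, a longer chain before the diethylamino group, or a piperidine in its place, also remains open.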